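The source may hold more compounds than are shown below. What is called first, only, known or untested is meant among the compounds shown, and "the series" means these compounds.

Compound 1 `COc1ccc(-c2cn3cc(C4=CCN(C(=O)c5ccccc5C(F)(F)F)CC4)ccc3n2)cc1OC`: 82900 nM
Compound 2 `COc1ccc(-c2cn3cc(C4=CCN(S(=O)(=O)C5CCCC5)CC4)ccc3n2)cc1OC`: 103000 nM

In an ADME assay on HEK293 cells (Homo sapiens) for cytotoxicity, read by MTT assay, with a stated time of 48 h (on this read-out lower numbers stand for stronger inhibition and higher numbers for weaker inhibition), compound 2 stands at the highest of these two numbers, and its nearest neighbour is compound 1; the step of a 1.2-fold higher number from compound 1 to compound 2 (0.09 log units; within the scatter) is small. Compound 3 `COc1ccc(-c2cn3cc(C4=CCN(C(=O)c5cccc(C(F)(F)F)c5)CC4)ccc3n2)cc1OC` differs from compound 2 by (3-(trifluoromethyl)phenyl)carbonyl in place of cyclopentylsulfonyl on an amine nitrogen in a ring. For the measured compounds named here, the one measured step that bears on this, a 1.2-fold higher number from compound 1 to compound 2 (0.09 log units; within the scatter), exchanged a (2-(trifluoromethyl)phenyl)carbonyl for the cyclopentylsulfonyl without leaving the scatter, so the present exchange is expected to move this assay by no more than the scatter, in either direction. Compound 3 is therefore estimated at 85000 nM, in the range 40000 nM to 180000 nM, a step of a 1.2-fold lower number from compound 2 to compound 3 (0.08 log units; within the scatter).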

Compound 3, half-maximal inhibitory concentration: 68400 nM
Compound 3: the middle estimate sits 1.2-fold (0.09 log units) above what was measured, within the range that was stated.
By their numbers in this assay, from the lowest: compounds 3, 1 and 2 (each within the scatter of the next).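

In this assay, the exchange on the amine nitrogen gives a 1.5-fold lower number from compound 2 to compound 3 (0.18 log units; within the scatter), so a second aryl carbonyl group also stays within the scatter of the cyclopentylsulfonyl group. Putting 3-(trifluoromethyl)phenyl in place of 2-(trifluoromethyl)phenyl on the carbonyl carbon gives a 1.2-fold lower number from compound 1 to compound 3 (0.08 log units; within the scatter), so this read-out does not separate these two groups. No supporting evidence is available to explain these numbers. As far as these compounds go, whether a carboxylic acid or an amine on the phenyl ring, or a longer alkyl chain on the ring nitrogen, would move this number beyond the scatter stays open.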